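The source may report more compounds than this note shows. Statements on the series, on what has been measured and on what is new or still open speak of the compounds shown alone.

Measured so far in an assay on HeLa cells for displacement of a labelled ligand from 5-hydroxytryptamine receptor 6 (Homo sapiens); a lower number here means a stronger inhibitor, a higher number a weaker inhibitor:
Compound 1 `O=S(=O)(c1cccc(F)c1)c1cn(C2CCNC2)c2ncccc12`: 2.7 nM
Compound 2 `CN1CCC(n2cc(S(=O)(=O)c3cccc(Cl)c3)c3cccnc32)C1`: 1.5 nM
Compound 3 `CCN1CCC(n2cc(S(=O)(=O)c3cccc(F)c3)c3cccnc32)C1`: 8.3 nM

Compound 3 stands highest of the three numbers. Its nearest neighbour is compound 1, and the step of a 3.1-fold higher number from compound 1 to compound 3 (0.49 log units; beyond the scatter) lies beyond the scatter. Compound 2 shows the lowest number of the three, but it differs from compound 3 in two places, so its value on its own says nothing about a single change.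

Compound 4 `CCN1CCC(n2cc(S(=O)(=O)c3cccc(Cl)c3)c3cccnc32)C1` differs from compound 3 by chloro in place of fluoro on an aromatic carbon. For the measured compounds named here, no measured step isolates this change: the only measured step, a 3.1-fold higher number from compound 1 to compound 3 (0.49 log units; beyond the scatter), concerns the amine nitrogen, not the aromatic ring. Compound 2, which carries chloro, gives the lowest number, yet also carries a methyl on the amine nitrogen. Compound 4 is therefore expected to move only slightly toward a lower number, within or near the scatter, a 1.5-fold lower number from compound 3 to compound 4 (0.18 log units; within the scatter). The estimate for compound 4 in this assay is 5.5 nM, ranging from 2.2 nM to 14 nM.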

Compound 4, inhibition constant: 3.3 nM
For compound 4 the middle estimate is 1.7-fold (0.22 log units) above the measured one; the range from low to high includes it.
By their numbers in this assay, from the lowest: compounds 2, 1 and 4 (each within the scatter of the next, the first and the last beyond it); then compound 3.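

In this assay, for the compounds shown here, this place on the aromatic ring responds to the halogen: 3-fluorophenyl to 3-chlorophenyl gives a 2.5-fold lower number from compound 3 to compound 4 (0.40 log units; beyond the scatter), the first reading that isolates this change. With chloro held, ethyl in place of methyl on the ring amine nitrogen gives a 2.2-fold higher number from compound 2 to compound 4 (0.34 log units; beyond the scatter), the same direction as a 3.1-fold higher number from compound 1 to compound 3 (0.49 log units; beyond the scatter) with fluoro. Nothing available accounts for either trend. From the compounds shown here alone, whether bromo, trifluoromethyl or methoxy at this place would lower the number further remains open. So does whether a propyl chain on the amine nitrogen would continue the rise.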